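From chloro to cyano: compound 3 and compound 4

The source may hold more compounds than are shown below. What is called first, only, known or untested is meant among the compounds shown, and "the series" means these compounds.

Measured in a functional assay on RAW264.7 cells (Mus musculus) for inhibition, read by Griess assay, with stated times of 1 h and 24 h; on this read-out higher numbers stand for weaker inhibition and lower numbers for stronger inhibition:
compound 1 `CCOc1ccc(C(O)C2OC(=O)c3c(OC)cc(OC)cc32)cc1`: > 10000 nM (a limit of the assay, not a number)
compound 2 `COCCCCOc1ccc(C(O)C2OC(=O)c3c(OC)cc(OC)cc32)cc1`: 8210 nM
compound 3 `COc1cc(OC)c2c(c1)C(C(O)c1ccc(OCc3ccc(Cl)cc3)cc1)OC2=O`: 4320 nM

Only compound 2 and compound 3 have actual numbers, and a 1.9-fold lower number from compound 2 to compound 3 (0.28 log units; within the scatter) keeps them together. Compound 1 reports only a limit. Measured against that limit, 4-chlorophenyl in place of methyl gives an at least 2.3-fold lower number from compound 1 to compound 3 (0.36 log units; beyond the scatter), while 2-methoxyethyl in place of hydrogen gives an at least 1.2-fold lower number from compound 1 to compound 2 (0.08 log units; that floor lies within the scatter).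

Compound 4 `COc1cc(OC)c2c(c1)C(C(O)c1ccc(OCc3ccc(C#N)cc3)cc1)OC2=O` carries cyano in place of chloro on an aromatic carbon, para to a large group (cyano in place of chloro on an aromatic carbon). Going by the values given here, none of the measured steps changes this substituent, so their sizes offer no direct guide to this exchange. The expectation therefore rests on compound 3 at 4320 nM. In this assay, no change beyond the scatter is expected, and the expected step is a 1.2-fold higher number from compound 3 to compound 4 (0.06 log units; within the scatter). Compound 4 is estimated at 5000 nM, with an expected range from 2200 nM to 10000 nM.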

Compound 4, half-maximal inhibitory concentration: 7360 nM
Beside the measured number, compound 4's estimate is 1.5-fold (0.17 log units) below it; low and high end bracket the measured number.
By their numbers in this assay, from the lowest: compounds 3, 4 and 2 (each within the scatter of the next). At a limit, above all of these: compound 1.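

In this assay, cyano in place of chloro on this aromatic carbon, para to a large group, gives a 1.7-fold higher number from compound 3 to compound 4 (0.23 log units; within the scatter), so this exchange does not separate the pair. The exchange of 3-methoxypropyl for 4-cyanophenyl gives a 1.1-fold lower number from compound 2 to compound 4 (0.05 log units; within the scatter), which again leaves no distinction between a saturated ether chain and this aromatic group. The exchange of methyl for 4-cyanophenyl gives an at least 1.3-fold lower number from compound 1 to compound 4 (0.13 log units; that floor lies within the scatter), a floor resting on a limit of the assay, and unlike the 4-chlorophenyl exchange it does not establish a change beyond the scatter: the limit of > 10000 nM in this assay, at which 1 of the 4 values shown sits.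

Open, going by these compounds, is whether an amine, a carboxylic acid or a trifluoromethyl group on this aromatic carbon would move the number beyond the scatter. On these data alone, the shared core is constant across all four compounds, so its part in the read-out remains unknown.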